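Lengthening the Ester Chain of Compound 1

The source may report more compounds than this note shows. Statements on the series, on what has been measured and on what is new or still open speak of the compounds shown alone.

Compound 1 `COc1ccc(N(C)c2nc(C)nc3ccccc23)cc1C(=O)OCCCCC[Se]C#N` gives 592 nM in a functional assay on A549 cells (Homo sapiens) for inhibition, read by MTT assay, with a stated time of 48 h (a lower number here means a stronger inhibitor, a higher number a weaker inhibitor), the higher of the two numbers recorded. Compound 2 `C[Se]c1ccc(N(C)c2nc(C3CC3)nc3ccccc23)cc1` gives 13 nM in this assay, a gap from compound 1 well beyond the scatter. Compound 3 `COc1ccc(N(C)c2nc(C)nc3ccccc23)cc1C(=O)OCCCCCC[Se]C#N` has not been measured; it differs from compound 1 by a group of 4 heavy atoms (2 carbon, 1 nitrogen, 1 selenium; no ring) in place of a group of 3 heavy atoms (1 carbon, 1 nitrogen, 1 selenium; no ring), on a saturated chain carbon, five bonds along the chain from an oxygen next to a carbonyl group. The change only lengthens the saturated chain that carries the group. Within the data shown here, no measured pair isolates such a change, so the step of a 1.1-fold lower number from compound 1 to compound 3 (0.03 log units; within the scatter) is expected to stay within the scatter, in no set direction. Compound 3 is estimated at 550 nM in this assay, with a range of 250 nM to 1300 nM.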

Compound 3, half-maximal inhibitory concentration: 488 nM
Compound 3: the middle estimate sits 1.1-fold (0.05 log units) above what was measured; low and high end bracket the measured number.
By their numbers in this assay, from the lowest: compound 2; then compounds 3 and 1 (each within the scatter of the next).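

Adding one carbon to the saturated chain gives, in this assay, a 1.2-fold lower number from compound 1 to compound 3 (0.08 log units; within the scatter). Among these compounds, this is the first measured pair to isolate this change, and at this position the two chain lengths cannot be told apart. No supporting evidence bears on this result. The compounds shown leave open whether a longer chain or a shorter chain would also stay within the scatter of compound 1. They also leave open what an amine or a carboxylic acid would give in place of the selenium-bearing group.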